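Tert-Butyl Ester to Primary Amide on the Urea Chain

The source may report more compounds than this note shows. Statements on the series, on what has been measured and on what is new or still open speak of the compounds shown alone.

Compound 1 `COC(=O)CNC(=O)NCc1ccc(C(=O)N2CCCCc3ccccc32)cc1C` and compound 2 `Cc1cc(C(=O)N2CCCCc3ccccc32)ccc1CNC(=O)NCC(=O)OC(C)(C)C` share the same core and differ only at the ester end of the urea chain. In a functional assay on HEK293 cells for agonist activity at Vasopressin V2 receptor (Homo sapiens), read by a luciferase reporter and cAMP accumulation (a higher number here means that more compound is needed for the effect, a lower number that less compound is needed), compound 1 gives 37 nM, and compound 2 gives 120 nM. Going by the values given here, the single measured step, a 3.2-fold higher number from compound 1 to compound 2 (0.51 log units; beyond the scatter), puts compound 2 at the higher of the two numbers, its nearest neighbour being compound 1.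

Compound 3 `Cc1cc(C(=O)N2CCCCc3ccccc32)ccc1CNC(=O)NCC(N)=O` is derived from compound 2 by amino in place of tert-butoxy on a carbonyl carbon. Among the compounds with values here, no measured step exchanges an ester for an amide, so the comparison rests on the one step available: a 3.2-fold higher number from compound 1 to compound 2 (0.51 log units; beyond the scatter), in which a larger alkyl group on the ester oxygen raised the number. Going from compound 2 to compound 3 removes that alkyl group along with its oxygen, which is read here as pointing back toward the region of compound 1 rather than further away from it.

On that basis compound 3 is expected to give 45 nM, with a range from 12 nM to 170 nM. The expected step is a 2.7-fold lower number from compound 2 to compound 3 (0.43 log units; beyond the scatter), a modest decrease that could still fall within the scatter.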

Compound 3, half-maximal effective concentration: 210 nM
Compound 3: middle estimate off by 4.7-fold (0.67 log units), on the low side, outside the stated range (above it).
By their numbers in this assay, from the lowest: compound 1; then compounds 2 and 3 (each within the scatter of the next).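

In this assay, amino in place of tert-butoxy on the carbonyl carbon gives a 1.8-fold higher number from compound 2 to compound 3 (0.24 log units; within the scatter), so the two compounds cannot be told apart, even though tert-butoxy, with its 5 heavy atoms, leaves and amino, with 1, enters. Set against the methyl ester, the primary amide gives a 5.7-fold higher number from compound 1 to compound 3 (0.75 log units; beyond the scatter), which is beyond the scatter and similar in kind to a 3.2-fold higher number from compound 1 to compound 2 (0.51 log units; beyond the scatter), so methoxy stands alone among the three groups seen on this carbonyl carbon, and the number does not run with the heavy-atom count of the group there, as amino and tert-butoxy lie at the two ends of that count yet sit together. Nothing available explains why these groups give these numbers.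

Going by these compounds, it remains open whether the lower number of compound 1 belongs to esters of small alcohols generally or to methoxy alone, and an ethoxy group or a free carboxylic acid on the same carbonyl carbon would bear on that. Also open, on these data alone, is how a methylamino group in place of amino, or a longer chain in place of carbamoylmethyl, would read in this assay.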